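Swapping Bromo for Amino on a Shared Core

This account rests on a few compounds, and the source may have more. Where it says the series, first, only, none or still open, it means among the compounds named here.

Measured so far in a functional assay on HeLa cells (Homo sapiens) for cytotoxicity, read by neutral red uptake, with a stated time of 3 days; a higher number here means a weaker inhibitor, a lower number a stronger inhibitor:
Compound 1 `CCCCc1c(F)c(N)c2c(=O)cc(-c3ccc(N)c(F)c3)oc2c1F` gives > 100000 nM in this assay.
Compound 2 `Nc1ccc(-c2cc(=O)c3c(N)c(F)c(Br)c(F)c3o2)cc1F` gives > 100000 nM in this assay.

The reading for compound 1 is a limit of the assay, not a number. The reading for compound 2 is likewise a limit, so compound 2 sits at the limit of > 100000 nM in this assay, at which 2 of the 2 values shown sit, and its true potency is not pinned down. Among the measured compounds shown here, the only measured step, a step that the two limits leave unreadable from compound 1 to compound 2, joins two limits and therefore cannot be read in size or direction.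

Compound 3 `Nc1ccc(-c2cc(=O)c3c(N)c(F)c(N)c(F)c3o2)cc1F` has not yet been measured. Its difference from compound 2 is amino in place of bromo on an aromatic carbon. For the measured compounds named here, no measured step bears readably on this change, and compound 2 itself sits at a limit, so the data give no direction to expect. Compound 3 is therefore estimated at 150000 nM, within a range from 40000 nM to 600000 nM, which means an expected step that the limit leaves unreadable from compound 2 to compound 3, none beyond the scatter.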

Compound 3, half-maximal inhibitory concentration: 19000 nM
Beside the measured number, compound 3's estimate is 7.9-fold (0.90 log units) above it; the whole stated range lies above it.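

In this assay, among the compounds shown here, the aromatic carbon ortho to two fluoro groups is the first place where a change on the shared core gives a readable result: amino in place of bromo brings an at least 5.2-fold lower number from compound 2 to compound 3 (0.72 log units; beyond the scatter). Amino in place of butyl at the same carbon brings an at least 5.2-fold lower number from compound 1 to compound 3 (0.72 log units; beyond the scatter), so among the three groups shown, only amino gives a measured number rather than a limit. The true size of both steps stays open, since each starts from a compound at a limit: the limit of > 100000 nM in this assay, at which 2 of the 3 values shown sit.

The compounds shown do not tell whether another group on nitrogen, such as methylamino or an acetamide, would match amino at this carbon. They also leave open how a hydroxyl or a shorter chain such as methyl would compare.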